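Replacing chloro with methyl on a weak growth inhibitor

The compounds below may be only part of what the source reports. "The series", "measured", "known", "first", "only" and "open" are said of these compounds alone.

Compound 1 `O=C(CCSc1ccc2c(/C=C/c3ccccn3)n[nH]c2c1)Nc1ccccc1`: 690 nM
Compound 2 `O=C(CCSc1ccc2c(/C=C/c3ccccn3)n[nH]c2c1)Nc1cccc(F)c1`: 6590 nM
Compound 3 `O=C(CCSc1ccc2c(/C=C/c3ccccn3)n[nH]c2c1)Nc1cccc(Cl)c1`: 9350 nM

These values come from an ADME assay on BaF3 cells (Mus musculus) for antiproliferative activity, read by CCK-8 assay, with a stated time of 72 h; on this read-out lower numbers stand for stronger inhibition of growth and higher numbers for weaker inhibition of growth. Compound 3 sits at the high, weak end of this small set, together with compound 2, and the gap between them is small: a 1.4-fold higher number from compound 2 to compound 3 (0.15 log units; within the scatter). The next compound, compound 4 `Cc1cccc(NC(=O)CCSc2ccc3c(/C=C/c4ccccn4)n[nH]c3c2)c1`, carries methyl in place of chloro on an aromatic carbon, meta to a large group: methyl in place of chloro on an aromatic carbon.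

Two measured steps show what adding a group here did: a 9.6-fold higher number from compound 1 to compound 2 (0.98 log units; beyond the scatter), and a 14-fold higher number from compound 1 to compound 3 (1.13 log units; beyond the scatter). Both were sizeable. Swapping one added group for the other, however, barely moved the number, as the step between compound 2 and compound 3 shows. For the measured compounds named here, no measured compound carries a methyl, so any forecast stays loose, but the closest guide is that small swap, not the large steps. The expected size of the change is a 1.6-fold lower number from compound 3 to compound 4 (0.19 log units; within the scatter), which would be no real shift beyond the scatter. For compound 4 the estimated value is 6000 nM, with an expected range of 1800 nM to 14000 nM.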

Compound 4, concentration for 50% growth inhibition: > 10000 nM
Compound 4: only a limit was reported; the forecaster's own chance of this, stated with the estimate: 5%; middle value at least 1.6-fold (0.22 log units) away from the limit.
By their numbers in this assay, from the lowest: compound 1; then compounds 2 and 3 (each within the scatter of the next). At a limit, above all of these: compound 4.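

In this assay compound 4 gave only a limit of the assay, > 10000 nM, rather than a number. Replacing hydrogen with methyl gives an at least 14-fold higher number from compound 1 to compound 4 (1.16 log units; beyond the scatter), so methyl, like fluoro and chloro, weakens growth inhibition at this place on the ring, and the effect is not confined to the two halogens. Comparison with those two halogen compounds settles less, with an at least 1.0-fold higher number from compound 3 to compound 4 (0.02 log units; that floor lies within the scatter) and an at least 1.5-fold higher number from compound 2 to compound 4 (0.18 log units; that floor lies within the scatter), so methyl cannot be ranked against chloro or fluoro.

As far as these compounds go, it remains open whether any group at this place can match compound 1, for example a hydroxyl or an amine, or whether hydrogen alone does so. From the compounds shown here alone, how far compound 4 lies past its limit also remains unknown, and a number for it would be needed to rank it.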